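A few compounds are considered here, and "the series" means these few. Any claim that something is new, unique, unknown or untested is made for them only; others in the source may bear on it.

Among the compounds with values here, compound 1 `O=C(Nc1cccc2[nH]ncc12)NC1CCc2cc(Br)ccc21` gives 9 nM in an assay on isolated protein for inhibition of transient receptor potential cation channel subfamily V member 1 (Homo sapiens), read by calcium flux (a lower number here means a stronger inhibitor, a higher number a weaker inhibitor), the lowest of the two numbers so far. Compound 2 `CC(C)(C)c1ccc2c(c1)CC[C@H]2NC(=S)Nc1cccc2[nH]ncc12` gives 97 nM in this assay, a gap from compound 1 that lies beyond the scatter. Compound 3 `Cc1ccc2c(c1)CCC2NC(=O)Nc1cccc2[nH]ncc12` differs from compound 1 by methyl in place of bromo on an aromatic carbon. Within the data shown here, no measured pair shows this exchange, so its direction is untested here. The expected step from compound 1 is a modest one, a 2.2-fold higher number from compound 1 to compound 3 (0.35 log units; beyond the scatter), toward a somewhat higher number. Compound 3 is estimated at 20 nM, with a range of 6 nM to 70 nM.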

Compound 3, half-maximal inhibitory concentration: 11 nM
Estimate against measurement, compound 3: 1.8-fold (0.26 log units) above; the range from low to high includes it.
By their numbers in this assay, from the lowest: compounds 1 and 3 (each within the scatter of the next); then compound 2.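

Methyl in place of bromo on an aromatic carbon gives a 1.2-fold higher number from compound 1 to compound 3 (0.09 log units; within the scatter), the first step read at this position in this assay. Here, meta to a fused ring and para to a fused ring, the core tolerates either group without a step beyond the scatter, which compound 2 could not show as it differs from compound 1 in more than one place. No measurement on hand explains this result.
Going by these compounds, whether a hydroxyl, an amine or a carboxylic acid on this carbon would hold the number remains open. So does whether a longer chain would.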